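The source may report more compounds than this note shows. Statements on the series, on what has been measured and on what is new or still open speak of the compounds shown alone.

Compound 1 `C=CCOC(=O)SCCCCCCNC(=O)c1cc(-c2ccncc2)n[nH]1`: 36000 nM
Compound 2 `CCCC(=O)SCCCCCCNC(=O)c1cc(-c2ccncc2)n[nH]1`: > 50000 nM

In a functional assay on MDA-MB-231 cells (Homo sapiens) for inhibition, read by MTT assay, with a stated time of 96 h (on this read-out lower numbers stand for stronger inhibition of growth and higher numbers for weaker inhibition of growth), compound 2 stands at > 50000 nM, which is a limit of the assay and not a number. Among the compounds with values here, this leaves compound 1 as the only compound with an exact value so far.

The next compound is compound 3 `CSCCCCCCNC(=O)c1cc(-c2ccncc2)n[nH]1`, with methyl in place of propylcarbonyl on a sulfur.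

No measurement covers this exchange directly. Within the data shown here, the only measured step is an at least 1.3-fold higher number from compound 1 to compound 2 (0.14 log units; that floor lies within the scatter). That step changes what sits on a carbonyl carbon, whereas here the whole propylcarbonyl leaves, so it bears on the new change only loosely. With compound 1 at 36000 nM as the one exact reference, no step beyond the scatter is expected in this assay. Compound 3 may well be reported only as a limit again.

The estimated step is a number no higher from compound 2 to compound 3 (the limit leaves the size open). For compound 3 the expected value is 50000 nM. The estimated range for compound 3 runs from 28000 nM to 90000 nM.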

Compound 3, concentration for 50% growth inhibition: > 50000 nM
Compound 3 gave a limit, no number; the forecaster's own chance of this, stated with the estimate: 65%; the middle value sits exactly at the limit.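

In this assay compound 3 gives > 50000 nM, which is a limit of the assay and not a number. Set against the only exact value in the series, replacing the allyloxycarbonyl on the sulfur with methyl gives an at least 1.3-fold higher number from compound 1 to compound 3 (0.14 log units; that floor lies within the scatter), so this change cannot be said to weaken growth inhibition. The step from compound 2 to compound 3 cannot be read, so swapping propylcarbonyl for methyl on this sulfur gives no measurable difference, and the series adds a second compound without adding a second exact value: the limit of > 50000 nM in this assay, at which 2 of the 3 values shown sit.

The compounds shown leave open whether any group on this sulfur can give a value clearly lower than that of compound 1, and what a free thiol or a hydroxamic acid in this place would read in this assay. Within the data shown here, they also leave open how a shorter or longer chain than the saturated one carrying the sulfur would behave, and with only one exact value, no trend can yet be drawn for this position.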